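A few compounds are considered here, and "the series" means these few. Any claim that something is new, unique, unknown or untested is made for them only; others in the source may bear on it.

Measured so far:
Compound 1, `OC[C@H]1O[C@@H](n2cnc3c(SCc4cccc(Br)c4)ncnc32)[C@H](O)[C@@H]1O`: 20.5 nM
Compound 2, `OC[C@H]1O[C@@H](n2cnc3c(SCc4ccccc4Cl)ncnc32)[C@H](O)[C@@H]1O`: 99.5 nM

Both numbers come from an assay on K562 cells for displacement of a labelled ligand from Equilibrative nucleoside transporter 1 (Homo sapiens); on this read-out higher numbers stand for weaker inhibition and lower numbers for stronger inhibition. Going by the values given here, the one measured step, a 4.9-fold higher number from compound 1 to compound 2 (0.69 log units; beyond the scatter), goes with 2-chlorophenyl in place of 3-bromophenyl on a saturated chain carbon bound to a sulfur, and it leaves compound 1 with the lowest of the two numbers, its nearest neighbour being compound 2. Compound 3, `OC[C@H]1O[C@@H](n2cnc3c(SCc4cccc(Cl)c4)ncnc32)[C@H](O)[C@@H]1O`, has not yet been measured. It differs from compound 1 by chloro in place of bromo on an aromatic carbon; the halogen sits on an aromatic carbon of a six-membered aromatic ring of carbon only, meta to a large group. Among the compounds with values here, no measured step swaps one halogen for another at the same place, and the step to compound 2 changes both the halogen and its position, so it bears only loosely here. A small swap of this kind is expected to move this assay little, if at all beyond the scatter. Compound 3 is therefore estimated at 30 nM, with a range of 12 nM to 75 nM. This means an expected step of a 1.5-fold higher number from compound 1 to compound 3 (0.17 log units; within the scatter).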

Compound 3, inhibition constant: 16 nM
For compound 3 the middle estimate is 1.9-fold (0.27 log units) above the measured one; the measured number falls inside the stated range.
By their numbers in this assay, from the lowest: compounds 3 and 1 (each within the scatter of the next); then compound 2.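

In this assay, chloro in place of bromo on the aromatic carbon gives a 1.3-fold lower number from compound 1 to compound 3 (0.11 log units; within the scatter), so at this place the two halogens cannot be told apart. Compounds 2 and 3 both carry chlorine and differ only in where it sits, and 3-chlorophenyl in place of 2-chlorophenyl gives a 6.2-fold lower number from compound 2 to compound 3 (0.79 log units; beyond the scatter). The earlier step from compound 1 to compound 2 changed the halogen and its place together, whereas these two steps separate the changes: among these three compounds, the place of the halogen goes with a difference beyond the scatter, and its identity does not, though no measurement here offers an explanation for that.

Going by these compounds, it remains open whether the same aromatic carbon would accept a group other than a halogen, such as methoxy, an amine or a carboxylic acid. On these data alone, how the unsubstituted phenyl ring compares also remains open.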